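This account rests on a few compounds, and the source may have more. Where it says the series, first, only, none or still open, it means among the compounds named here.

In an ADME assay on the whole organism with Oryza sativa as the target, tested at 10 uM (on this read-out lower numbers stand for a stronger effect and higher numbers for a weaker effect at the one concentration tested), compound 1 `Cc1cccc(NC(=O)N[C@@H](C)c2ccccc2)c1` gives 100%, compound 2 `C[C@@H](NC(=O)Nc1cccc(C(F)(F)F)c1)c1ccccc1` gives 70%, and compound 3 `C[C@H](NC(=O)Nc1cccc(C(F)(F)F)c1)c1ccccc1` gives 92%. Compound 3 thus stands second highest of the three numbers: its nearest neighbour is compound 1, within the scatter, and the furthest is compound 2. The step of a number 22 percentage points higher from compound 2 to compound 3 (beyond the scatter) is a modest change, and it rests on (the fact that compounds 2 and 3 differ only in the configuration as drawn). The step of a number 8 percentage points lower from compound 1 to compound 3 (within the scatter) shows that swapping the group on the aromatic carbon of the shared core barely moves the number.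

Compound 4 `COc1cccc(NC(=O)N[C@@H](C)c2ccccc2)c1` is the next compound to be measured. It differs from compound 3 in one place: methoxy in place of trifluoromethyl on an aromatic carbon. Among the measured compounds shown here, the measured step that bears on this change is the one from compound 1 to compound 3, since it also exchanges the group on the same aromatic carbon while keeping the drawn configuration; that step stayed within the scatter. The configuration change between compound 2 and compound 3 does not apply here. Compound 4 keeps the configuration of compound 3. The step expected in this assay from compound 3 to compound 4 is therefore a number 3 percentage points higher from compound 3 to compound 4 (within the scatter), within the scatter, with no clear direction. Compound 4 is estimated to give 95%, somewhere between 76% and 100%.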

Compound 4, a percentage reported as activity, at one concentration (the size of the read-out at that concentration, not a potency): 99%
Estimate against measurement, compound 4: 4 percentage points below; measured number inside the range.
By their numbers in this assay, from the lowest: compound 2; then compounds 3, 4 and 1 (each within the scatter of the next).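

In this assay, a number 7 percentage points higher from compound 3 to compound 4 (within the scatter) and a number 1 percentage points lower from compound 1 to compound 4 (within the scatter) show that a third group on this aromatic carbon leaves the number within the scatter of the other two. Methoxy differs from trifluoromethyl in size and adds a hydrogen-bond acceptor, going by the counts of heavy atoms and acceptors, so this position now tolerates three different groups without a readable change in the configuration drawn for compounds 1, 3 and 4, whereas the earlier compounds offered only a single exchange of group. No measurement shown here gives a reason for this flat result, and the only known difference between compound 2 and compound 3 concerns configuration, not the group exchanged here.

As far as these compounds go, it remains open whether methoxy or methyl on this aromatic carbon would give a number near that of compound 2 in its drawn configuration, which would show whether the group matters there. From the compounds shown here alone, it also remains open whether a group of another kind at this place, such as an amine or a carboxylic acid, would move the number beyond the scatter.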